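The source may hold more compounds than are shown below. What is called first, only, known or untested is meant among the compounds shown, and "the series" means these compounds.

Working notes on a pair of hydroxamates built on one shared core. Among the compounds with values here, compound 1 `O=C(NO)[C@@H]1CSCN1S(=O)(=O)c1ccc(-c2ccccc2)cc1` gives 230 nM in an assay on isolated protein for inhibition of matrix metalloproteinase-9 (Homo sapiens), read by fluorescence, with stated times of 1 h and 30 min (on this read-out lower numbers stand for stronger inhibition and higher numbers for weaker inhibition), the lowest of the two numbers so far; compound 2 `O=C(NO)[C@@H]1CCCN1S(=O)(=O)c1ccc(-c2ccccc2)cc1` gives 76000 nM, a higher number, beyond the scatter. Compound 3 `O=C(NO)[C@@H]1CSCN1S(=O)(=O)c1ccc(Oc2ccc(Cl)cc2)cc1`, not yet measured, differs from compound 1 by 4-chlorophenoxy in place of phenyl on an aromatic carbon. Within the data shown here, no measured pair shows this change, so its size is open. The step of a 1.5-fold lower number from compound 1 to compound 3 (0.19 log units; within the scatter) is expected to be small, a modest move toward a lower number, close to the scatter. Compound 3 is estimated at 150 nM, within 40 nM to 700 nM.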

Compound 3, half-maximal inhibitory concentration: 16 nM
Compound 3: the middle estimate sits 9.4-fold (0.97 log units) above what was measured, outside the stated range (below it).
By their numbers in this assay, from the lowest: compound 3; then compound 1; then compound 2.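

This aromatic carbon, para to a large group, tolerates a larger substituent in this assay: 4-chlorophenoxy in place of phenyl gives a 14-fold lower number from compound 1 to compound 3 (1.16 log units; beyond the scatter) and is the change that moves the number furthest down among the compounds shown. Compounds 1 and 2 carry the same phenyl here and so gave no reading of this position. Nothing available explains the size of this step.

Open, from the compounds shown here alone, is whether the ether oxygen or the chlorine carries the step, which phenoxy and 4-chlorophenyl would separate. Also open, going by these compounds, is whether the step holds on the core of compound 2.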